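The source may hold more compounds than are shown below. What is called first, only, known or untested is meant among the compounds shown, and "the series" means these compounds.

Measured so far in a functional assay on HeLa cells (Homo sapiens) for cytotoxicity, read by MTT assay, with a stated time of 48 h; on this read-out lower numbers stand for stronger inhibition and higher numbers for weaker inhibition:
compound 1 `COc1cc(C(=O)NC2CCN(C)CC2)ccc1Nc1ncc(Br)c(NC2CCCC2)n1`: 3500 nM
compound 2 `CN1CCC(NC(=O)c2ccc(Nc3ncc(Cl)c(NC4CCCC4)n3)cc2)CC1`: 1500 nM

Compound 2 stands at the lower of the two numbers in this assay. Compound 1 differs from it in more than one place, carrying a methoxy group that compound 2 lacks as well as a bromo substituent where compound 2 has chloro, and its number lies beyond the scatter above that of compound 2. Going by the values given here, since the two are not a single-point pair, no step between them is counted; the pair shows only what its two values show.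

Compound 3 `CN1CCC(NC(=O)c2ccc(Nc3ncc(Br)c(NC4CCCC4)n3)cc2)CC1` is the one still to be measured in this assay. It differs from compound 2 in a single place: bromo in place of chloro on an aromatic carbon. Among the compounds with values here, no measured pair isolates this exchange, and the distance between compound 1 and compound 2 cannot be attributed to it alone. The expected step is therefore small, in no clear direction, and likely within the scatter. Compound 3 is estimated at 2000 nM, with a range from 900 nM to 4500 nM. This estimate amounts to an expected step of a 1.3-fold higher number from compound 2 to compound 3 (0.12 log units; within the scatter).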

Compound 3, half-maximal inhibitory concentration: 900 nM
Compound 3: the middle estimate sits 2.2-fold (0.35 log units) above what was measured; the measured number falls inside the stated range.
By their numbers in this assay, from the lowest: compounds 3 and 2 (each within the scatter of the next); then compound 1.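

Bromo in place of chloro on the aromatic carbon ortho to a cyclopentylamino group, two atoms from the ring nitrogen, gives a 1.7-fold lower number from compound 2 to compound 3 (0.22 log units; within the scatter) in this assay, so this exchange is now isolated for the first time and the two halogens cannot be told apart at this position in this read-out. Going by these compounds alone, the methoxy group can now also be looked at alone: with bromo held in place on both compounds, hydrogen in place of methoxy on an aromatic carbon gives a 3.9-fold lower number from compound 1 to compound 3 (0.59 log units; beyond the scatter), the only single-place step here that lies beyond the scatter, though it rests on one pair. Nothing in the available data explains either step.

The compounds shown leave open whether a fluoro, a nitrile or a trifluoromethyl group at the halogen position would stay within the scatter of compound 2 and compound 3. They also leave open whether the step seen on removing methoxy would recur on the chloro series, and how an ethoxy or a hydroxy group would read at that place.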